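The source may hold more compounds than are shown below. What is called first, only, known or untested is meant among the compounds shown, and "the series" means these compounds.

Measured compounds:
Compound 1, `COc1ccc(-c2cc3nccc(-c4cc(OC)c(OC)c(OC)c4)n3n2)cc1[N+](=O)[O-]` — in a functional assay on A549 cells (Homo sapiens) for inhibition, read by CCK-8 assay, with a stated time of 48 h (on this read-out lower numbers stand for stronger inhibition and higher numbers for weaker inhibition), compound 1 reaches only the limit of the assay, > 10000 nM.
Compound 2, `COc1cc(-c2ccnc3cc(-c4ccc(C(C)=O)cc4)nn23)cc(OC)c1OC` — in this assay compound 2 gives 4100 nM.
Compound 3, `COc1cc(-c2ccnc3cc(-c4ccc(N(C)C)cc4)nn23)cc(OC)c1OC` — in this assay compound 3 gives 1100 nM.

For the measured compounds named here, compound 3 therefore holds the lowest of the two numbers measured so far. Going by the values given here, the only step between two measured numbers is a 3.7-fold lower number from compound 2 to compound 3 (0.57 log units; beyond the scatter), dimethylamino in place of acetyl on an aromatic carbon, a modest shift. Compound 4, `COc1ccc(-c2cc3nccc(-c4cc(OC)c(OC)c(OC)c4)n3n2)cc1`, differs from compound 3 by methoxy in place of dimethylamino on an aromatic carbon. Among the compounds with values here, no measured step touches a methoxy at this position, so the one step available shows only that the group para to the large group moves the number modestly. Compound 4 is expected to give about 2500 nM, with a range from 800 nM to 8000 nM. This estimate means an expected step of a 2.3-fold higher number from compound 3 to compound 4 (0.36 log units; beyond the scatter), still within or near the scatter.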

Compound 4, half-maximal inhibitory concentration: 376 nM
Beside the measured number, compound 4's estimate is 6.6-fold (0.82 log units) above it, outside the stated range (below it).
By their numbers in this assay, from the lowest: compound 4; then compound 3; then compound 2. At a limit, above all of these: compound 1.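

In this assay, methoxy on this aromatic carbon, para to a large group, gives the lowest number of the series, with a 2.9-fold lower number from compound 3 to compound 4 (0.47 log units; beyond the scatter) and an 11-fold lower number from compound 2 to compound 4 (1.04 log units; beyond the scatter). Hydrogen in place of nitro on an aromatic carbon brings a larger change, an at least 26-fold lower number from compound 1 to compound 4 (1.42 log units; beyond the scatter). That step rests on a limit and not a number: the limit of > 10000 nM in this assay, at which 1 of the 4 values shown sits.

The compounds shown leave open how a hydroxyl, an ethoxy or a primary amine at this position would compare with methoxy. They also leave open why the three groups fall in this order.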